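Moving the chlorine from compound 3 to compound 4

A few compounds are considered here, and "the series" means these few. Any claim that something is new, unique, unknown or untested is made for them only; others in the source may bear on it.

Measured in a functional assay on NCI-H460 cells (Homo sapiens) for cytotoxicity, read by sulforhodamine B assay; on this read-out lower numbers stand for higher toxicity in this test and higher numbers for lower toxicity in this test:
compound 1 `CC1=CC[C@@H]([C@@](C)(O)CCCC(C)(C)NC(=S)N/N=C\c2ccc(N(C)C)cc2)CC1` gives > 100000 nM as a limit
compound 2 `CC1=CC[C@@H]([C@@](C)(O)CCCC(C)(C)NC(=S)N/N=C\c2ccccc2[N+](=O)[O-])CC1` gives > 100000 nM as a limit
compound 3 `CC1=CC[C@@H]([C@@](C)(O)CCCC(C)(C)NC(=S)N/N=C\c2ccccc2Cl)CC1` gives > 100000 nM as a limit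

Compound 3 stands with > 100000 nM as a limit and not a number, so it has no readable place in the series. The measured set shares one limit (the limit of > 100000 nM in this assay, at which 3 of the 3 values shown sit). Compound 4 `CC1=CC[C@@H]([C@@](C)(O)CCCC(C)(C)NC(=S)N/N=C\c2ccc(Cl)cc2)CC1` has 4-chlorophenyl in place of 2-chlorophenyl on a carbon with a double bond to nitrogen. Bearing on this change are three measured steps (a step that the two limits leave unreadable from compound 1 to compound 2 and a step that the two limits leave unreadable from compound 1 to compound 3 and a step that the two limits leave unreadable from compound 2 to compound 3) and none gives a size to carry over. The expected step (a number no higher from compound 3 to compound 4 (the limit leaves the size open)) is none beyond the scatter and has no expected direction in this assay. For compound 4 the estimated value is 100000 nM with an expected range from 40000 nM to 200000 nM and a limit reading is again likely.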

Compound 4, concentration lethal to 50% of the cells: > 100000 nM
Compound 4: no number, only a limit; the forecaster's own chance of this, stated with the estimate: 85%; the middle value lies on the limit itself.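

Compound 4 adds no readable step from compound 1, compound 2 or compound 3, because each reading is a limit and not a number: the limit of > 100000 nM in this assay, at which 4 of the 4 values shown sit.

As far as these compounds go, whether any of these aryl changes alters the read-out in this assay stays open.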